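The source may report more compounds than this note shows. Statements on the series, on what has been measured and on what is new or still open speak of the compounds shown alone.

Of the compounds shown here, three have been tested in a functional assay on MDA-MB-231 cells (Homo sapiens) for cytotoxicity, read by MTT assay, with a stated time of 72 h; a higher number here means a weaker inhibitor, a lower number a stronger inhibitor. Compound 1, with the structure `Cc1ccc(CNC(=S)Nc2ccc(C(=O)Nc3ccccc3N)cc2)cn1`, gives 63000 nM, the lowest of the two numbers recorded. Its nearest neighbour is compound 3, with the structure `Nc1ccccc1NC(=O)c1ccc(NC(=O)NCc2ccc(F)nc2)cc1`, which gives 91000 nM; the two values lie within the usual scatter of each other, so neither can be called the stronger. For compound 2, with the structure `Nc1ccccc1NC(=O)c1ccc(Cn2cc(-c3ccc(NC(=O)NCc4cccnc4)cc3)nn2)cc1`, the assay reports only a limit, > 100000 nM, not a number.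

Compound 4, with the structure `Nc1ccccc1NC(=O)c1ccc(NC(=S)NCc2cccc(Cl)c2)cc1`, has not yet been measured. It differs from compound 1 in one place: 3-chlorophenyl in place of 6-methylpyridin-3-yl on a saturated chain carbon bound to an amide-type nitrogen. Within the data shown here, no measured pair shows this kind of change, so its effect is not known from these data. The expectation for compound 4 is a value of about 50000 nM in this assay, estimated to lie between 18000 nM and 140000 nM. That estimate means a step of a 1.3-fold lower number from compound 1 to compound 4 (0.10 log units; within the scatter), expected to stay within the scatter rather than beyond it.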

Compound 4, half-maximal inhibitory concentration: 92000 nM
Beside the measured number, compound 4's estimate is 1.8-fold (0.26 log units) below it, within the range that was stated.
By their numbers in this assay, from the lowest: compounds 1, 3 and 4 (each within the scatter of the next). At a limit, above all of these: compound 2.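

Among these compounds, replacing 6-methylpyridin-3-yl with 3-chlorophenyl, on a saturated chain carbon bound to an amide-type nitrogen, is the first change in one place that can be read in this assay, and it gives a 1.5-fold higher number from compound 1 to compound 4 (0.16 log units; within the scatter). At this position, then, a carbon-only ring carrying chlorine takes the place of a ring with a nitrogen and a methyl group, with no difference that these data can separate from the scatter. Compound 2 gives a limit, not a number: the limit of > 100000 nM in this assay, at which 1 of the 4 values shown sits.

Still open, from the compounds shown here alone, is whether a group of another kind at this position, such as a carboxylic acid, an amine or a morpholine ring, would move the number beyond the scatter. A longer chain between the ring and the amide-type nitrogen also remains untested in the compounds shown here.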